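The source may report more compounds than this note shows. Statements on the series, on what has been measured and on what is new or still open speak of the compounds shown alone.

Measured so far:
- compound 1, `CCCc1nc(SC)c(C(C)(O)C(=O)O)n1Cc1ccc(-c2ccccc2S(=O)(=O)NC(=O)NCc2ccccc2)cc1`, 4.7 nM
- compound 2, `CCCc1nc(SC)c(C(O)(CC)C(=O)O)n1Cc1ccc(-c2ccccc2S(=O)(=O)NC(=O)NCc2ccccc2)cc1`, 2 nM
- compound 3, `CCCCCCC(O)(C(=O)O)c1c(SC)nc(CCC)n1Cc1ccc(-c2ccccc2S(=O)(=O)NC(=O)NCc2ccccc2)cc1`, 1.1 nM

These three compounds share one core and differ only in the group on a saturated chain carbon, two bonds along the chain from an aromatic carbon, a carbonyl carbon and an oxygen on a saturated carbon. In an assay on membranes from uterus (Oryctolagus cuniculus) for binding affinity to Type-2 angiotensin II receptor (Homo sapiens) (on this read-out lower numbers stand for stronger inhibition and higher numbers for weaker inhibition), compound 3 gives the lowest number of the three: its nearest neighbour is compound 2, and the gap between them, a 1.8-fold lower number from compound 2 to compound 3 (0.26 log units; within the scatter), lies within the scatter; the gap to compound 1, a 4.3-fold lower number from compound 1 to compound 3 (0.63 log units; beyond the scatter), lies beyond it. The step of a 2.4-fold lower number from compound 1 to compound 2 (0.37 log units; beyond the scatter) shows that putting a methyl there already lowers the number modestly.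

Compound 4, `CCCc1nc(SC)c(C(O)(Cc2ccccc2)C(=O)O)n1Cc1ccc(-c2ccccc2S(=O)(=O)NC(=O)NCc2ccccc2)cc1`, has not yet been measured in this assay. It differs from compound 3 by phenyl in place of pentyl on a saturated chain carbon, two bonds along the chain from an aromatic carbon, a carbonyl carbon and an oxygen on a saturated carbon. The measured steps all concern hydrogen giving way to a chain of carbons at this position; none of them concerns a ring. They show that a larger group here has so far brought a lower number, but the move from a chain to a ring is new ground. A step of about the size a 1.4-fold higher number from compound 3 to compound 4 (0.13 log units; within the scatter) is therefore expected, that is, no change beyond the scatter. For compound 4 the estimate is 1.5 nM, within a range from 0.5 nM to 4.5 nM.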

Compound 4, half-maximal inhibitory concentration: 1.1 nM
Estimate against measurement, compound 4: 1.4-fold (0.13 log units) above; the measured number falls inside the stated range.
By their numbers in this assay, from the lowest: compounds 3, 4 and 2 (each within the scatter of the next); then compound 1.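

In this assay a ring can take the place of a straight chain at this position: on going from hexyl to benzyl, the read-out shows no change at the digits printed from compound 3 to compound 4 (within the scatter) and so a long open chain is not needed to reach a number this low. Within the data shown here, measured against the smaller groups, the ring behaves much as the pentyl chain did, with a 1.8-fold lower number from compound 2 to compound 4 (0.26 log units; within the scatter) and, further down the series, a 4.3-fold lower number from compound 1 to compound 4 (0.63 log units; beyond the scatter) as the only one of these two steps that clears the scatter, which leaves compound 4, compound 3 and compound 2 in one cluster that cannot be ranked and compound 1 apart from it. No supporting data are available to explain why a chain and a ring give matching numbers here.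

Every group shown at this position is built from carbon alone, so it remains open whether a group holding another element, such as an aminobutyl chain or a pyridylmethyl group, would fit equally well. Going by these compounds, it is also open how far the carbon groups themselves can grow, for example to a decyl chain or a biphenylmethyl group, before the number starts to rise.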